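Methoxy for chloro: expected cytotoxicity of compound 3

A few compounds are considered here, and "the series" means these few. Any claim that something is new, unique, unknown or untested is made for them only; others in the source may bear on it.

Compound 1 `Fc1ccc2c(Cn3cncn3)c(-c3ccc(Cl)cc3)[nH]c2c1` and compound 2 `Clc1ccc(-c2[nH]c3cc(Cl)ccc3c2Cn2cncn2)cc1` share one core and differ at a single aromatic carbon. In an ADME assay on MCF7 cells (Homo sapiens) for cytotoxicity, read by MTT assay, with a stated time of 48 h (a lower number here means a stronger inhibitor, a higher number a weaker inhibitor), compound 1 gives only a limit, > 1000000 nM. In this assay, within the data shown here, compound 2 gives 382000 nM, the single number among the two values. The other value, that of compound 1, is a limit (the limit of > 1000000 nM in this assay, at which 1 of the 2 values shown sits). The step of an at least 2.6-fold lower number from compound 1 to compound 2 (0.41 log units; beyond the scatter) is the only measured one. Compound 3 `COc1ccc2c(Cn3cncn3)c(-c3ccc(Cl)cc3)[nH]c2c1` differs from compound 2 by methoxy in place of chloro on an aromatic carbon. Among the measured compounds shown here, no measured step involves a methoxy, so the halogen swap is the sole guide and the direction is open. Compound 3 is expected near 500000 nM in this assay, between 150000 nM and 2000000 nM. The step of a 1.3-fold higher number from compound 2 to compound 3 (0.12 log units; within the scatter) is expected to lie within the scatter.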

Compound 3, half-maximal inhibitory concentration: 612000 nM
Beside the measured number, compound 3's estimate is 1.2-fold (0.09 log units) below it, and the stated range covers the measured number.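

In this assay, among these compounds, methoxy and chloro are not separated at this aromatic carbon, a first reading for a group with an oxygen there: a 1.6-fold higher number from compound 2 to compound 3 (0.20 log units; within the scatter). Against fluoro, the step is an at least 1.6-fold lower number from compound 1 to compound 3 (0.21 log units; that floor lies within the scatter). Compound 1 stands at a limit, so this step is only a floor: the limit of > 1000000 nM in this assay, at which 1 of the 3 values shown sits.

The compounds shown leave open whether an amine, a carboxylic acid or a longer chain such as ethoxy at this position would move the number beyond the scatter. Going by these compounds, how changes elsewhere on the shared core would read also stays open.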